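Chloro to Fluoro: Expecting the Cytotoxicity of Compound 4

This account rests on a few compounds, and the source may have more. Where it says the series, first, only, none or still open, it means among the compounds named here.

Compound 1 `CCOC(=O)c1c(-c2cc3ccccc3oc2=O)nn(-c2cccc(Cl)c2)c1C(=O)OCC` was tested in a functional assay on DU-145 cells (Homo sapiens) for cytotoxicity, read by MTT assay, with a stated time of 48 h (on this read-out higher numbers stand for weaker inhibition and lower numbers for stronger inhibition), where compound 1 gives 35000 nM. Compound 3 `CCOC(=O)c1c(-c2cc3ccccc3oc2=O)nn(-c2cccc(F)c2)c1C(=O)OCC` differs from it by fluoro in place of chloro on an aromatic carbon; in this assay compound 3 gives 32000 nM, so that a 1.1-fold lower number from compound 1 to compound 3 (0.04 log units; within the scatter). Compound 2 `COC(=O)c1c(-c2cc3ccccc3oc2=O)nn(-c2cccc(Cl)c2)c1C(=O)OC` has a different core from compound 1, and the difference between the two cores is not broken down here. In this assay compound 2 gives 32000 nM. Within the data shown here, compound 4 `COC(=O)c1c(-c2cc3ccccc3oc2=O)nn(-c2cccc(F)c2)c1C(=O)OC` has not yet been measured; it differs from compound 2 by fluoro in place of chloro on an aromatic carbon, the same change at the same place as the one from compound 1 to compound 3. The step is expected to be a 1.1-fold lower number from compound 2 to compound 4 (0.03 log units; within the scatter) because a 1.1-fold lower number from compound 1 to compound 3 (0.04 log units; within the scatter) stayed within the scatter. Compound 4 is therefore estimated to give 30000 nM, with a likely range from 15000 nM to 60000 nM.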

Compound 4, half-maximal inhibitory concentration: 37000 nM
Estimate against measurement, compound 4: 1.2-fold (0.09 log units) below; low and high end bracket the measured number.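

In this assay, the change of chloro to fluoro gives a 1.2-fold higher number from compound 2 to compound 4 (0.06 log units; within the scatter). Set beside the earlier step, the two cores do not differ measurably in how they take this change: the same change on two cores in this assay, a 1.1-fold lower number (0.04 log units; within the scatter) from compound 1 to compound 3 and a 1.2-fold higher number (0.06 log units; within the scatter) from compound 2 to compound 4, 1.3-fold (0.10 log units) apart, within the scatter of two such steps. On these two cores, then, the 3-chlorophenyl to 3-fluorophenyl swap leaves the number within the scatter each time, but two pairs cannot show that the same would hold on other cores or in other assays.

The compounds shown carry only chloro or fluoro on this ring, so the outcome with a methoxy group, an amine or a carboxylic acid there remains open. The esters shown are only methyl and ethyl, which leaves open what a longer chain or an amide would give.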